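The source may report more compounds than this note shows. Statements on the series, on what has been measured and on what is new or still open speak of the compounds shown alone.

Compound 2 `O=C(CSc1nc(Nc2ccccc2)c2ccccc2n1)Nc1cccc(Cl)c1` gives 8460 nM in a functional assay on NCI-H1975 cells (Homo sapiens) for inhibition, read by MTT assay, with a stated time of 72 h; a lower number here means a stronger inhibitor, a higher number a weaker inhibitor; of the two numbers shown it is the smaller, but the step of a 1.2-fold lower number from compound 1 to compound 2 (0.09 log units; within the scatter) lies within the scatter, so compound 2 and compound 1 `O=C(CSc1nc(Nc2ccccc2)c2ccccc2n1)Nc1ccccc1Br`, at 10300 nM, are not told apart. Compound 3 `O=C(CSc1nc(Nc2ccccc2)c2ccccc2n1)Nc1cccc(Br)c1` differs from compound 2 by bromo in place of chloro on an aromatic carbon, meta to a large group. Going by the values given here, only the step from compound 1 to compound 2 bears on this, and that halogen swap stayed within the scatter, so no step beyond the scatter is expected in this assay. Compound 3 is therefore estimated at 8000 nM, range 3000 nM to 20000 nM, a step of a 1.1-fold lower number from compound 2 to compound 3 (0.02 log units; within the scatter).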

Compound 3, half-maximal inhibitory concentration: 10100 nM
Beside the measured number, compound 3's estimate is 1.3-fold (0.10 log units) below it; low and high end bracket the measured number.
By their numbers in this assay, from the lowest: compounds 2, 3 and 1 (each within the scatter of the next).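

In this assay, bromo in place of chloro on the aromatic carbon gives a 1.2-fold higher number from compound 2 to compound 3 (0.08 log units; within the scatter), so the two halogens are not told apart at this place. 3-Bromophenyl in place of 2-bromophenyl gives a 1.0-fold lower number from compound 1 to compound 3 (0.01 log units; within the scatter), so moving the bromo on the ring also produces no readable difference, which the earlier pair, differing in both halogen and place, could not show. No independent evidence bears on this result.

Still open, on these data alone, is whether any group on this ring moves the number beyond the scatter, for example a methoxy, an amine or a carboxylic acid.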